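The source may hold more compounds than are shown below. What is called first, only, known or untested is meant among the compounds shown, and "the series" means these compounds.

Compound 3 `CC(C)n1ncc2c(C(=O)NCc3cn(-c4cccc(Br)c4)nn3)cccc21` gives only a limit of the assay in a functional assay on MGC-803 cells (Homo sapiens) for inhibition, read by MTT assay, with a stated time of 72 h (a higher number here means a weaker inhibitor, a lower number a stronger inhibitor), namely > 40000 nM. Compound 1 `CC(C)n1ncc2c(C(=O)NC3CCCC3)cccc21` also reaches only a limit in this assay, at > 40000 nM. Compound 2 `CC(C)n1ncc2c(C(=O)NCc3ccccc3)cccc21` likewise stands at a limit in this assay, > 40000 nM. For the measured compounds named here, the one step among them, a step that the two limits leave unreadable from compound 1 to compound 2, cannot be read, and all three values sit at the limit of > 40000 nM in this assay, at which 3 of the 3 values shown sit. Compound 4 `COc1ccc(-n2cc(CNC(=O)c3cccc4c3cnn4C(C)C)nn2)cc1` differs from compound 3 by 4-methoxyphenyl in place of 3-bromophenyl on an aromatic nitrogen. Going by the values given here, no measured step touches this aromatic nitrogen, so none bears on the change. With every value at the limit, the step that the limit leaves unreadable from compound 3 to compound 4 is expected to stay within the scatter, and compound 4 is expected most likely to return a limit again. Compound 4 is estimated at 60000 nM, with a range from 20000 nM to 200000 nM.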

Compound 4, half-maximal inhibitory concentration: > 40000 nM
Compound 4 was reported as a limit (the forecaster's own chance of this, stated with the estimate: 85%); the middle value lies beyond the limit too.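

No new step can be read, since compound 3 and compound 4 both stand at a limit: the limit of > 40000 nM in this assay, at which 4 of the 4 values shown sit.

The compounds shown leave open how strongly any of them inhibits in this assay, and whether exchanging 3-bromophenyl for 4-methoxyphenyl changes that at all.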